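The source may hold more compounds than are shown below. What is called first, only, known or untested is meant among the compounds shown, and "the series" means these compounds.

Measured so far in an ADME assay on L1210/0 cells (Mus musculus) for cytotoxicity, with a stated time of 48 h; a higher number here means a weaker inhibitor, a lower number a stronger inhibitor:
- Compound 1 `CC1(C)[C@@H](Cn2ccc(=O)[nH]c2=O)CC[C@@]1(C)CO` gives > 200000 nM as a limit
- Compound 2 `O=c1[nH]c(=O)n([C@H]2C[C@H](O)[C@@H](CO)O2)cc1/C=N/O` gives 15500 nM as a number

The value of compound 1 is a limit of the assay and not a number. Within the data shown here, compound 2 at 15500 nM therefore holds the only true number, and it cannot yet be ranked against a second number.

Compound 3 `O=c1[nH]c(=O)n([C@H]2C[C@H](O)[C@@H](CO)O2)cc1CO` is still to be measured in this assay and differs from compound 2 in one place. A hydroxymethyl stands in place of a group of 3 heavy atoms on an aromatic carbon, as counted in a group of 2 heavy atoms (1 carbon, 1 oxygen; no ring) in place of a group of 3 heavy atoms (1 carbon, 1 nitrogen, 1 oxygen; no ring), on an aromatic carbon with the rest of the structure unchanged.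

Among the measured compounds shown here, no measured pair differs in one place, so the data give no direct size for a change of this kind. The working expectation is no shift beyond the usual scatter, with wide uncertainty in both directions. The expected move is a 1.6-fold lower number from compound 2 to compound 3 (0.19 log units; within the scatter) and rests only on the number of compound 2 at 15500 nM as an anchor. For compound 3 the estimated value is 10000 nM with an expected range from 1500 nM to 80000 nM as the working bounds.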

Compound 3, half-maximal inhibitory concentration: 9180 nM
For compound 3 the middle estimate is 1.1-fold (0.04 log units) above the measured one, within the range that was stated.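

In this assay, this position, on an aromatic carbon two atoms from the ring nitrogen, now has its first readable step: hydroxymethyl in place of the group of 3 heavy atoms gives a 1.7-fold lower number from compound 2 to compound 3 (0.23 log units; within the scatter). The exchange removes the double bond outside aromatic rings and leaves the shared core unchanged, yet the two compounds cannot be told apart in this assay, so this one change at this position leaves the reading within the scatter. Compound 1 holds a limit of the assay rather than a number, and it has no step to either of the other compounds: the limit of > 200000 nM in this assay, at which 1 of the 3 values shown sits.

Among these compounds, these two compounds span only one exchange at one position, so how an amine, a carboxylic acid or a longer chain on the same aromatic carbon would read in this assay remains open. It is also open whether the same exchange would give a similar step on another core, and the data shown give no cause for the size of this step.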